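The compounds below may be only part of what the source reports. "The series", "measured", "known", "first", "only" and "open" are said of these compounds alone.

Compound 1 `O=C(CCc1ccccc1)Nc1nc2ccccc2c(=O)s1` is the anchor of this small set: in an assay on CHO cells for displacement of a labelled ligand from adenosine receptor A1 (Homo sapiens), read by scintillation counting, with a stated time of 90 min (a lower number here means a stronger inhibitor, a higher number a weaker inhibitor), compound 1 gives 1050 nM. Compound 2 `O=C(CCc1ccccc1F)Nc1nc2ccccc2c(=O)s1` carries a 2-fluorophenyl group where compound 1 carries a plain phenyl, but for compound 2 the result in this assay is recorded only as "not determined" (no result reported), so compound 2 stands on no single number, and the only measured reference point is the value of compound 1.

Compound 3 `O=C(CCCc1cccc(Cl)c1)Nc1nc2ccccc2c(=O)s1` takes the step from compound 2 by the change (3-chlorobenzyl in place of 2-fluorophenyl on a saturated chain carbon, two bonds along the chain from a carbonyl carbon). Among the measured compounds shown here, with no measured step between any two compounds of the set, the size of this move in this assay can only be guessed; the account expects at most a modest shift, quite possibly none beyond the scatter, relative to what the phenyl-bearing compound 1 shows. Compound 3 is therefore estimated at 1500 nM in this assay, with an expected range from 400 nM to 6000 nM.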

Compound 3, inhibition constant: > 10000 nM
Compound 3: a limit, no number (the forecaster's own chance of this, stated with the estimate: 10%); at least 6.6-fold (0.82 log units) between middle value and limit.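

Among the compounds shown here, the step from phenyl to 3-chlorobenzyl on a saturated chain carbon, two bonds along the chain from a carbonyl carbon, gives the first readable comparison at this position in this assay: an at least 9.5-fold higher number from compound 1 to compound 3 (0.97 log units; beyond the scatter). This shows that the number in this assay responds to the group at this place, and that this change moves it in the weaker direction, beyond the scatter. The result for compound 3 is a limit and not a number: the limit of > 10000 nM in this assay, at which 1 of the 3 values shown sits.

For the compounds shown here, compound 2 offers no step that can be read, so the 2-fluorophenyl group adds nothing to this comparison, and how far compound 3 lies past its limit stays unknown. Also open, on these data alone, is how much of the step belongs to the chlorine and how much to the benzyl carbon, which a plain benzyl group at this place would help to separate.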